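Moving the alcohol: a second hydroxyl-bearing phenyl variant

A few compounds are considered here, and "the series" means these few. Any claim that something is new, unique, unknown or untested is made for them only; others in the source may bear on it.

Compound 1 `CCCC[S+]([O-])c1sc2nc(-c3nccs3)cc(-c3ccc(C(=O)OC)cc3)c2c1N`: 15.1 nM
Compound 2 `CCCC[S+]([O-])c1sc2nc(-c3nccs3)cc(-c3ccc(CNS(C)(=O)=O)cc3)c2c1N`: 4.6 nM
Compound 3 `CCCC[S+]([O-])c1sc2nc(-c3nccs3)cc(-c3cccc(CO)c3)c2c1N`: 4.3 nM

These three compounds share one core and differ only in the aryl group attached to it. In an assay for inhibition of 15-hydroxyprostaglandin dehydrogenase [NAD(+)] (Homo sapiens), read by fluorescence, with a stated time of 15 min, in the presence of a further agent that is not named here (a higher number here means a weaker inhibitor, a lower number a stronger inhibitor), compound 3 gives the lowest number of the three, yet compound 2 sits within the usual scatter of it, so the two cannot be ranked; only compound 1 stands clearly apart. Compound 4 `CCCC[S+]([O-])c1sc2nc(-c3nccs3)cc(-c3ccc(C(C)(C)O)cc3)c2c1N` has not been measured. The change is 4-(1-hydroxy-1-methylethyl)phenyl in place of 3-(hydroxymethyl)phenyl on an aromatic carbon. For the measured compounds named here, two measured steps touch this part of the molecule: a 3.3-fold lower number from compound 1 to compound 2 (0.52 log units; beyond the scatter) and a 3.5-fold lower number from compound 1 to compound 3 (0.55 log units; beyond the scatter). Going by the values given here, both show that swapping the methoxycarbonyl-bearing aryl for a hydroxyl- or sulfonamide-bearing one helps, but neither compares two hydroxyl-bearing groups against each other, so the present step has no direct precedent. The expected step is therefore small, a 1.2-fold higher number from compound 3 to compound 4 (0.07 log units; within the scatter), with no clear direction beyond the scatter. Compound 4 is estimated at 5 nM, within 2 nM to 13 nM.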

Compound 4, half-maximal inhibitory concentration: 3.6 nM
Compound 4: the middle estimate sits 1.4-fold (0.14 log units) above what was measured, and the stated range covers the measured number.
By their numbers in this assay, from the lowest: compounds 4, 3 and 2 (each within the scatter of the next); then compound 1.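

In this assay, a bulkier alcohol on the aryl ring fits this position as well as the earlier groups: the change from 3-(hydroxymethyl)phenyl to 4-(1-hydroxy-1-methylethyl)phenyl gives a 1.2-fold lower number from compound 3 to compound 4 (0.08 log units; within the scatter), and replacing (methanesulfonamido)methyl gives a 1.3-fold lower number from compound 2 to compound 4 (0.11 log units; within the scatter). Replacing methoxycarbonyl gives a 4.2-fold lower number from compound 1 to compound 4 (0.62 log units; beyond the scatter), so a third group now stands clearly apart from the ester. No measurement shown here explains these numbers. The step to compound 4 changes the alcohol's ring position and its carbon branching together, so the two changes cannot be separated. As far as these compounds go, whether a carboxylic acid or an amine would serve here remains open.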